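The compounds below may be only part of what the source reports. "The series", "measured", "known", "first", "only" and "open" are said of these compounds alone.

Among the measured compounds shown here, compound 1 `NCCSCCc1c[nH]c2ccc(F)cc12` gives 8 nM in an assay on isolated protein for inhibition of Myeloperoxidase (Homo sapiens), read by ELISA, with a stated time of 5 min (a higher number here means a weaker inhibitor, a lower number a stronger inhibitor), the lowest of the three numbers measured so far. Compound 3 `NC(=O)CCCc1c[nH]c2ccc(F)cc12` gives 18 nM in this assay, and compound 2 `NC(=O)CCc1c[nH]c2c(F)cccc12` gives 64 nM. For the measured compounds named here, the only single-point step measured, a 2.3-fold higher number from compound 1 to compound 3 (0.35 log units; beyond the scatter), is also the only one that bears on compound 4 `CCSCCc1c[nH]c2ccc(F)cc12`, which differs from compound 1 by hydrogen in place of amino on a saturated chain carbon, two bonds along the chain from a sulfur. Altering this chain end in compound 3 already gave a modest loss, and compound 4 removes the amino rather than exchanging it, so a loss of similar or somewhat larger size is expected, with wide uncertainty. The step expected here is a 5.0-fold higher number from compound 1 to compound 4 (0.70 log units; beyond the scatter). Compound 4 is estimated at 40 nM in this assay, with a range of 10 nM to 160 nM.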

Compound 4, half-maximal inhibitory concentration: > 100 nM
Compound 4: no number, only a limit; the forecaster's own chance of this, stated with the estimate: 5%; middle value at least 2.5-fold (0.39 log units) from the limit.
By their numbers in this assay, from the lowest: compound 1; then compound 3; then compound 2. At a limit, above all of these: compound 4.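

Compound 4 stands at a limit of the assay, not at a number: the limit of > 100 nM in this assay, at which 1 of the 4 values shown sits. Hydrogen in place of amino gives an at least 12-fold higher number from compound 1 to compound 4 (1.09 log units; beyond the scatter), so the amino counts for more in this assay than the exchange for carbamoylmethyl did, at a 2.3-fold higher number from compound 1 to compound 3 (0.35 log units; beyond the scatter). Ethylsulfanyl in place of carbamoylmethyl gives an at least 5.5-fold higher number from compound 3 to compound 4 (0.74 log units; beyond the scatter), so the ethylsulfanyl chain alone does not carry the result.

On these data alone, the full size of both new steps stays unknown. Also open, as far as these compounds go, is whether a hydroxyl, a carboxylic acid, a dimethylamino group or a longer chain carrying the amine would hold the value of compound 1, 8 nM.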